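The source may report more compounds than this note shows. Statements on the series, on what has been measured and on what is new or still open speak of the compounds shown alone.

Measured compounds:
compound 1 `CONC(=O)c1ccccc1OC` — > 800000 nM
compound 2 `COc1ccccc1/C(N)=N/O` — > 800000 nM

In an ADME assay on Huh-7 cells (Homo sapiens) for cytotoxicity, read by MTT assay, with a stated time of 72 h (a higher number here means that more compound is tolerated, a lower number that less compound is tolerated), compound 1 gives > 800000 nM, which is a limit of the assay rather than a number. Compound 2 gives > 800000 nM in this assay, likewise a limit. Within the data shown here, compound 2 therefore stands nowhere on a scale of numbers: it sits at the limit of > 800000 nM in this assay, at which 2 of the 2 values shown sit, and the one other value shown sits there too. Among the measured compounds shown here, no step between measured compounds can be counted.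

Compound 3 `COc1ccccc1C(N)=O` differs from compound 2 by a group of 3 heavy atoms (1 carbon, 1 nitrogen, 1 oxygen; no ring) in place of a group of 4 heavy atoms (1 carbon, 2 nitrogen, 1 oxygen; no ring), on an aromatic carbon. With both known values at the limit, no step beyond the usual scatter is expected in this assay for this change, in either direction. Compound 3 is accordingly estimated at 1000000 nM, within 400000 nM to 3000000 nM, with the expectation that the assay will most likely again report only a limit. The step from compound 2 to compound 3 is thus estimated as a step that the limit leaves unreadable from compound 2 to compound 3.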

Compound 3, half-maximal cytotoxic concentration: > 800000 nM
Compound 3: no number, only a limit; the forecaster's own chance of this, stated with the estimate: 85%; the middle value does not contradict the limit.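

In this assay compound 3 gives > 800000 nM, a limit and not a number. No step from compound 1 or compound 2 to compound 3 can be read: the limit of > 800000 nM in this assay, at which 3 of the 3 values shown sit.

The compounds shown leave open at what concentration any of them becomes cytotoxic to these cells, and whether the changes among them alter that concentration.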